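A few compounds are considered here, and "the series" means these few. Any claim that something is new, unique, unknown or untested is made for them only; others in the source may bear on it.

Of the compounds shown here, two have been measured so far. Compound 1 `COc1ccc(-c2cc(/C=C/C(=O)c3ccc(N)cc3)[nH]n2)cc1` and compound 2 `COc1cc(-c2cc(/C=C/C(=O)c3ccc(Cl)c(Cl)c3)[nH]n2)cc(OC)c1OC` share a core and were both tested in a functional assay on HT-29 cells (Homo sapiens) for cytotoxicity, read by sulforhodamine B assay, with a stated time of 48 h, tested at 1 uM; on this read-out higher numbers stand for a weaker effect at the one concentration tested and lower numbers for a stronger effect. In this assay compound 1 gives 97%. In this assay compound 2 gives 96%, a number that lies within the usual scatter of the value of compound 1, so the two cannot be told apart, and both show hardly any effect at the single concentration tested. Compound 3 `COc1cc(-c2cc(/C=C/C(=O)c3ccc(F)c(F)c3)[nH]n2)cc(OC)c1OC` has not yet been measured. It differs from compound 2 in one place: 3,4-difluorophenyl in place of 3,4-dichlorophenyl on a carbonyl carbon. Going by the values given here, no step between measured compounds shows what such a change does here. With both measured compounds sitting close to no effect, the step expected for compound 3 in this assay is no change at the digits printed from compound 2 to compound 3 (within the scatter), nothing beyond the scatter. Compound 3 is therefore estimated at 96%, with a likely range from 85% to 104%.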

Compound 3, a percentage reported as activity, at one concentration (the size of the read-out at that concentration, not a potency): 103%
Beside the measured number, compound 3's estimate is 7 percentage points below it; the range from low to high includes it.
By their numbers in this assay, from the lowest: compounds 2, 1 and 3 (each within the scatter of the next).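

On the carbonyl carbon, 3,4-difluorophenyl in place of 3,4-dichlorophenyl gives a number 7 percentage points higher from compound 2 to compound 3 (within the scatter) in this assay. Going by these compounds alone, this is the first step here between two compounds that differ in one place, and it shows that exchanging the two chlorine atoms on this ring for two fluorine atoms leaves the two compounds impossible to tell apart at the one concentration tested. No independent data are available to explain this result.

On these data alone, whether a different kind of group on this carbonyl carbon, such as a carboxylic acid or a longer chain in place of the 3,4-difluorophenyl, would produce a clear effect in this assay remains open. Also open, as far as these compounds go, is how compound 2 and compound 3 would behave at higher concentrations, where a difference between them might or might not appear.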